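A few compounds are considered here, and "the series" means these few. Any claim that something is new, unique, unknown or untested is made for them only; others in the source may bear on it.

Measured compounds:
- Compound 1, `O=C(CCCCCc1ccccc1)c1nc2cc(F)ccc2o1`: in an assay on HEK-293T cells for inhibition of diacylglycerol lipase-alpha (Homo sapiens), read by colorimetric assay (a higher number here means a weaker inhibitor, a lower number a stronger inhibitor), compound 1 gives 1410 nM.
- Compound 2, `O=C(CCCCCCc1ccccc1)c1nc(C(=O)C(F)(F)F)co1`: in this assay compound 2 gives 123 nM.

Going by the values given here, of the two numbers measured so far, compound 2 holds the lower one, and compound 1 stands well above it. Compound 3, `O=C(CCCCCCc1ccccc1)c1nc(-c2ccncc2)co1`, has not yet been measured. It differs from compound 2 in a single exchange: pyridin-4-yl in place of (trifluoromethyl)carbonyl on an aromatic carbon. The (trifluoromethyl)carbonyl leaves and a pyridin-4-yl enters at the same aromatic carbon of the five-membered ring.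

Among the compounds with values here, no measured pair isolates this exchange, so the expected size of the step rests only on compound 2 and the nature of the change. A step toward a somewhat higher number, of a size that may not exceed the usual scatter, is estimated for a 2.4-fold higher number from compound 2 to compound 3 (0.39 log units; beyond the scatter). For compound 3 in this assay the estimate is 300 nM, with a range from 60 nM to 1500 nM.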

Compound 3, half-maximal inhibitory concentration: > 10000 nM
Compound 3 ended at the assay's limit; the forecaster's own chance of this, stated with the estimate: 5%; at least 33-fold (1.52 log units) between middle value and limit.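

In this assay compound 3 gives > 10000 nM, which is a limit of the assay and not a number. The exchange of (trifluoromethyl)carbonyl for pyridin-4-yl on this aromatic carbon, next to the ring nitrogen, leaves the rest of the molecule unchanged and gives an at least 81-fold higher number from compound 2 to compound 3 (1.91 log units; beyond the scatter), so this single position can by itself decide whether inhibition is seen in the measured range. The true size of the step stays unknown, and the printed figure is only a bound set by the assay: the limit of > 10000 nM in this assay, at which 1 of the 3 values shown sits.

Going by these compounds alone, the single exchange cannot separate the loss of the (trifluoromethyl)carbonyl from the arrival of the pyridin-4-yl. As far as these compounds go, how a nitrile, a methyl ester or a phenyl ring on the same carbon would read remains open.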